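The source may hold more compounds than are shown below. What is called first, only, known or untested is meant among the compounds shown, and "the series" means these compounds.

Working notes on the series in a functional assay (strain AB) with Danio rerio as the target, read by microscopy, with a stated time of 1 h (a higher number here means that more compound is needed for the effect, a lower number that less compound is needed), follow. Compound 1 `CCN1CCc2c(sc(NC(=O)Nc3ccccc3)c2C(N)=O)C1` reads > 25000 nM here, which is a limit and not a number. Going by the values given here, compound 2 `CCN1CCc2c(sc(NC(=O)Nc3ccc(Cl)cc3)c2C(N)=O)C1` reads 3120 nM and holds the only true number so far. Among the compounds with values here, the one measured step is an at least 8.0-fold lower number from compound 1 to compound 2 (0.90 log units; beyond the scatter) for chloro in place of hydrogen on an aromatic carbon, and its size rests on the limit of > 25000 nM in this assay, at which 1 of the 2 values shown sits, as its starting point. Compound 3 `CCN1CCc2c(sc(NC(=O)Nc3cccc(C)c3)c2C(N)=O)C1` comes next, and the change is 3-methylphenyl in place of 4-chlorophenyl on an amide-type nitrogen in the form of 3-methylphenyl in place of 4-chlorophenyl on an amide-type nitrogen. Within the data shown here, this takes away the chloro, so the step of an at least 8.0-fold lower number from compound 1 to compound 2 (0.90 log units; beyond the scatter) bears on it in reverse, though no measured compound carries a methyl group. Part of that step is expected to be lost, which points to a higher number in this assay and a move of moderate size. The expected move is a 2.9-fold higher number from compound 2 to compound 3 (0.46 log units; beyond the scatter) on this estimate. Compound 3 is estimated at 9000 nM with an expected range from 3000 nM to 25000 nM in this assay.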

Compound 3, half-maximal effective concentration: 13000 nM
For compound 3 the middle estimate is 1.4-fold (0.16 log units) below the measured one, within the range that was stated.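

In this assay, the swap of 4-chlorophenyl for 3-methylphenyl on the amide-type nitrogen gives a 4.2-fold higher number from compound 2 to compound 3 (0.62 log units; beyond the scatter), so two aryl groups of equal heavy-atom count are told apart at this position, and the lower number stays with the 4-chlorophenyl group. The other new step is an at least 1.9-fold lower number from compound 1 to compound 3 (0.28 log units; that floor lies within the scatter), so the printed floor of this step does not by itself separate the methyl group from the unsubstituted phenyl, whereas the chloro step from the earlier pair lies beyond the scatter. The reading of compound 1 is a limit and not a number, and the true size of that methyl step stays unknown with it: the limit of > 25000 nM in this assay, at which 1 of the 3 values shown sits.

The step between the two substituted phenyl groups changes both the group and its place on the ring in one move, so the share of each cannot be read from these compounds, and chloro and methyl are not compared at a single site. From the compounds shown here alone, how a methoxy group, an amine or a carboxylic acid on this phenyl ring would read stays open.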